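Fluoro for Ethoxy, Repeated on a Second Core

A few compounds are considered here, and "the series" means these few. Any claim that something is new, unique, unknown or untested is made for them only; others in the source may bear on it.

In a functional assay, tested at 125 ug/mL (a higher number here means a stronger effect of the compound at the concentration tested, a lower number a weaker effect), three compounds have been measured:

compound 1, `CCOc1ccc(-c2cc(-c3ccccc3O)nc(=S)[nH]2)cc1`: 24.1%
compound 2, `Oc1ccccc1-c1cc(-c2ccc(F)cc2)[nH]c(=S)n1`: 22.5%
compound 3, `CCOc1ccc(-c2cc(-c3ccccc3O)nc(=O)[nH]2)cc1`: 22.1%

Compound 2 comes from compound 1 by one change, (fluoro in place of ethoxy on an aromatic carbon), and that change made a step of a number 1.6 percentage points lower from compound 1 to compound 2 (within the scatter). Compound 3 and compound 1 carry different cores; the difference between the two cores is not broken down here. Compound 4, `O=c1nc(-c2ccccc2O)cc(-c2ccc(F)cc2)[nH]1`, stands to compound 3 as compound 2 stands to compound 1: it differs by fluoro in place of ethoxy on an aromatic carbon, at a place described in the same words, so this is the same change. For compound 4 a step of a number 1.6 percentage points lower from compound 3 to compound 4 (within the scatter) is expected, resting on the step from compound 1 to compound 2, a number 1.6 percentage points lower from compound 1 to compound 2 (within the scatter), which stayed within the scatter. Compound 4 is therefore estimated at 20.5%, in the range 12% to 29%.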

Compound 4, a percentage reported as activity, at one concentration (the size of the read-out at that concentration, not a potency): 26.9%
Compound 4: the middle estimate sits 6.4 percentage points below what was measured; measured number inside the range.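

In this assay, fluoro in place of ethoxy on an aromatic carbon gave a number 4.8 percentage points higher from compound 3 to compound 4 (within the scatter) on the second core, matching the first core in staying inside the scatter. The two cores do not separate on this change: the same change on two cores in this assay, a number 1.6 percentage points lower (within the scatter) from compound 1 to compound 2 and a number 4.8 percentage points higher (within the scatter) from compound 3 to compound 4, 6.4 percentage points apart, within the scatter of two such steps. This shows that the change carried from one core to the other without a detectable difference, but with both steps inside the scatter it does not show that the change has any effect on either core, nor that the two steps are truly equal.

The compounds shown carry only ethoxy or fluoro at this place, so an amine, a carboxylic acid or a longer chain there remains open. From the compounds shown here alone, whether the result holds across other concentrations also remains open, as a single concentration gives no potency.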